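Methyl on an Amine Nitrogen: Compound 3 to Compound 4

A few compounds are considered here, and "the series" means these few. Any claim that something is new, unique, unknown or untested is made for them only; others in the source may bear on it.

Of the compounds shown here, three have been measured in a functional assay on A2780 cells (Homo sapiens) for antiproliferative activity, read by MTT assay, with a stated time of 48 h; on this read-out lower numbers stand for stronger inhibition and higher numbers for weaker inhibition. Compound 1 `CNCC(=O)Nc1cc(OC)ccc1C(=O)c1ccc2c(c1)C=CC(C)(C)O2` gives 850 nM. Compound 2 `COc1ccc(C(=O)c2ccc3c(c2)C=CC(C)(C)O3)c(NC(=O)CN(C)C)c1` gives 1020 nM. Compound 3 `C=C(c1ccc(OC)cc1NC(=O)CN)c1ccc(OC)c2c1C=CC(C)(C)O2` gives 400 nM, the lowest of the three numbers; its steps to both other compounds are reported as beyond the usual scatter.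

Compound 1 and compound 2 differ in one place, (methyl in place of hydrogen on an amine nitrogen), and this change made a step of a 1.2-fold higher number from compound 1 to compound 2 (0.08 log units; within the scatter), a step that stays within the scatter. Compound 3 stands on a different core from compound 1, and the difference between the two cores is not broken down here.

Compound 4 `C=C(c1ccc(OC)cc1NC(=O)CNC)c1ccc(OC)c2c1C=CC(C)(C)O2` has not yet been measured in this assay. It differs from compound 3 by methyl in place of hydrogen on an amine nitrogen. Within the data shown here, this is the same kind of change as the one from compound 1 to compound 2, but not the same: in compound 1 the amine nitrogen has two saturated chain carbons as its other neighbours, whereas in compound 3 it has a single saturated chain carbon. Among the measured compounds shown here, the only measured step of this kind, a 1.2-fold higher number from compound 1 to compound 2 (0.08 log units; within the scatter), was small, and a similar step is expected here, so compound 4 is estimated to move by a 1.2-fold higher number from compound 3 to compound 4 (0.06 log units; within the scatter) from compound 3. Given this, compound 4 is expected to give 460 nM in this assay, with a range from 220 nM to 1000 nM, an expectation that rests only on the step from compound 1 to compound 2 and on the value of compound 3.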

Compound 4, half-maximal inhibitory concentration: 720 nM
Compound 4: middle estimate off by 1.6-fold (0.19 log units), on the low side; the measured number falls inside the stated range.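

In this assay, methyl in place of hydrogen on an amine nitrogen produced a 1.8-fold higher number from compound 3 to compound 4 (0.26 log units; within the scatter), so compound 3 and compound 4 cannot be told apart on this read-out. Set beside the earlier step, the change shows no difference between the two cores that stands clear of the scatter: the same change on two cores in this assay, a 1.2-fold higher number (0.08 log units; within the scatter) from compound 1 to compound 2 and a 1.8-fold higher number (0.26 log units; within the scatter) from compound 3 to compound 4, 1.5-fold (0.18 log units) apart, within the scatter of two such steps

This shows that, in these two pairs, the change carried from one core to the other without a step beyond the scatter, although the amine nitrogen of compound 1 has two saturated chain carbons as its other neighbours and that of compound 3 has only one; it does not show that the two steps are identical, that the change has no effect at all, or that the same would hold on any further core.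

The compounds shown leave open how a dimethylamino group would read on the core of compound 3, which would complete the set of hydrogen and methyl variants on that nitrogen. They also leave open what an ethyl group, a longer chain or a cyclic amine at that nitrogen would do on either core, since only hydrogen and methyl appear there as the entering or leaving group.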